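A few compounds are considered here, and "the series" means these few. Any claim that something is new, unique, unknown or untested is made for them only; others in the source may bear on it.

In a functional assay on MDA-MB-231 cells (Homo sapiens) for antiproliferative activity, read by MTT assay, with a stated time of 72 h (a higher number here means a weaker inhibitor, a lower number a stronger inhibitor), compound 1 `CC1=CC[C@H]2[C@H](CC[C@]2(C)O)C(C)(C)[C@@H]1CC[C@H]1[C@]2(C)CC[C@H](OC(=O)c3ccccc3)C(C)(C)O[C@H]2CC[C@@]1(C)O` gives 16100 nM and compound 2 `CC1=CC[C@H]2[C@H](CC[C@]2(C)O)C(C)(C)[C@@H]1CC[C@H]1[C@]2(C)CC[C@H](OC(=O)NCc3ccccc3)C(C)(C)O[C@H]2CC[C@@]1(C)O` gives 40300 nM. Compound 2 therefore holds the higher, weaker number of the two, and compound 1 supplies its nearest value. The next compound to be measured is compound 3 `CC1=CC[C@H]2[C@H](CC[C@]2(C)O)C(C)(C)[C@@H]1CC[C@H]1[C@]2(C)CC[C@H](OC(=O)c3ccc(C(F)(F)F)cc3)C(C)(C)O[C@H]2CC[C@@]1(C)O`. The structural change is 4-(trifluoromethyl)phenyl in place of benzylamino on a carbonyl carbon.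

Among the compounds with values here, only one measured step bears on this change. The step of a 2.5-fold higher number from compound 1 to compound 2 (0.40 log units; beyond the scatter) came with benzylamino in place of phenyl on a carbonyl carbon, and it was modest but beyond the scatter. Compound 3 gives up that benzylamino, so a step of similar modest size, towards a lower number, is expected in this assay on the evidence of a 2.5-fold higher number from compound 1 to compound 2 (0.40 log units; beyond the scatter). Within the data shown here, no measured compound carries the trifluoromethyl group, so the estimate stays broad.

For compound 3 the expected value is 15000 nM, with an estimated range of 6500 nM to 35000 nM. The estimated step is a 2.7-fold lower number from compound 2 to compound 3 (0.43 log units; beyond the scatter).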

Compound 3, half-maximal inhibitory concentration: 19500 nM
Estimate against measurement, compound 3: 1.3-fold (0.11 log units) below, and the stated range covers the measured number.
By their numbers in this assay, from the lowest: compounds 1 and 3 (each within the scatter of the next); then compound 2.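

In this assay, the comparison on this carbonyl carbon now rests on two aryl groups rather than one: a 2.1-fold lower number from compound 2 to compound 3 (0.32 log units; beyond the scatter), with 4-(trifluoromethyl)phenyl in place of benzylamino, so the gap seen earlier with the unsubstituted phenyl of compound 1 is not confined to that one group. Trifluoromethyl in place of hydrogen on an aromatic carbon gives a 1.2-fold higher number from compound 1 to compound 3 (0.08 log units; within the scatter), so this substitution does not separate the two aryl compounds, and compound 2 remains the only one of the three with a number set apart from the others. No measurement shown gives a reason for either step.

Still open, going by these compounds, is whether a nitrile, a methoxy group, an amine or a carboxylic acid on the phenyl ring would also leave the number unresolved from that of compound 1, since trifluoromethyl is the only substituent on that ring so far. A longer chain in place of benzylamino, or a substituted benzylamino group, would show whether the higher number of compound 2 40300 nM extends beyond that single group.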